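The compounds below may be only part of what the source reports. "The series", "measured", "known", "first", "only" and "open" are said of these compounds alone.

Working notes on the series, read in a functional assay on the whole organism with Rattus norvegicus as the target; on this read-out higher numbers stand for an effect only at larger amounts of compound and lower numbers for an effect already at smaller amounts. Compound 1 `CCN(CCNC(=O)c1cc(Cl)c(N)cc1OC)Cc1ccc(OC)cc1` gives 0.2 mg/kg. Compound 2 `CCN(CCNC(=O)c1cc(Cl)c(N)cc1OC)Cc1ccc(Cl)cc1` gives 0.24 mg/kg. Compound 3 `CCN(CCNC(=O)c1cc(Cl)c(N)cc1OC)Cc1ccc(F)cc1` gives 0.2 mg/kg. Compound 2 thus stands level with the other two, since all three numbers lie within the scatter of one another and no order can be read among them.

Compound 4 `COc1cc(N)c(Cl)cc1C(=O)NCCN(Cc1ccc(Cl)cc1)C(C)C` differs from compound 2 by one change: methyl in place of hydrogen on a saturated chain carbon bound to an amine nitrogen and a saturated chain carbon. Cut one bond further out, the same difference reads ethyl to isopropyl.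

The measured steps are a 1.2-fold higher number from compound 1 to compound 2 (0.08 log units; within the scatter), no change at the digits printed from compound 1 to compound 3 (within the scatter) and a 1.2-fold lower number from compound 2 to compound 3 (0.08 log units; within the scatter). All are within the scatter, and all are exchanges on an aromatic carbon. For the measured compounds named here, they bear on the new change only indirectly, as no measured pair varies a saturated chain carbon bound to an amine nitrogen and a saturated chain carbon. The data therefore give no size or direction for this change, and the estimate starts from compound 2 at 0.24 mg/kg, with a wide range.

No step beyond the scatter is expected in this assay, and the expected step is a 1.3-fold higher number from compound 2 to compound 4 (0.10 log units; within the scatter). Compound 4 is estimated at 0.3 mg/kg, with an expected range from 0.08 mg/kg to 0.9 mg/kg.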

Compound 4, dose for half-maximal effect: 3 mg/kg
For compound 4 the middle estimate is 10-fold (1.00 log units) below the measured one; measured number outside the range, above it.
By their numbers in this assay, from the lowest: compounds 1, 3 and 2 (each within the scatter of the next); then compound 4.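

In this assay, methyl in place of hydrogen on a saturated chain carbon bound to an amine nitrogen and a saturated chain carbon, which also reads as ethyl to isopropyl, gives a 13-fold higher number from compound 2 to compound 4 (1.10 log units; beyond the scatter) and so marks a large loss at this position. The exchanges among methoxy, chloro and fluoro on an aromatic carbon all stayed within the scatter, whereas this single added methyl gives the first step beyond it, so the series is shown to respond strongly to a change at this saturated chain carbon. No available measurement bears on the cause of this step.

The compounds shown leave open whether the step follows from the branch in isopropyl or from the added carbon alone, a question that a propyl group, as the longer unbranched chain, or a cyclopropyl group at this place would help to separate. They also leave open whether ethyl to isopropyl gives a step of similar size when methoxy or fluoro stands in place of chloro on the aromatic carbon.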